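Swapping 3-methoxyphenyl for 2-chlorophenyl

This account rests on a few compounds, and the source may have more. Where it says the series, first, only, none or still open, it means among the compounds named here.

In a functional assay on the whole organism with Rattus norvegicus as the target (a lower number here means that less compound is needed, a higher number that more compound is needed for the effect), compound 1 `CCN(CCNC(=O)c1cc(Cl)c(N)cc1OC)Cc1ccccc1` gives 0.31 mg/kg, and compound 2 `CCN(CCNC(=O)c1cc(Cl)c(N)cc1OC)Cc1cccc(OC)c1` gives 1 mg/kg, the higher of the two numbers. Compound 3 `CCN(CCNC(=O)c1cc(Cl)c(N)cc1OC)Cc1ccccc1Cl` carries 2-chlorophenyl in place of 3-methoxyphenyl on a saturated chain carbon bound to an amine nitrogen. Among the compounds with values here, the one measured step that bears on this is a 3.2-fold higher number from compound 1 to compound 2 (0.51 log units; beyond the scatter), a modest rise on adding methoxy. Within the data shown here, compound 3 lacks that methoxy but carries a chlorine, which no measured step covers. The expected change in this assay is therefore a smaller move towards lower numbers, a 2.0-fold lower number from compound 2 to compound 3 (0.30 log units; within the scatter). For compound 3 the estimated value is 0.5 mg/kg, within a range of 0.15 mg/kg to 1.7 mg/kg.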

Compound 3, dose for half-maximal effect: 10 mg/kg
Compound 3: the middle estimate sits 20-fold (1.30 log units) below what was measured; measured number outside the range, above it.
By their numbers in this assay, from the lowest: compound 1; then compound 2; then compound 3.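

Chloro in place of hydrogen on an aromatic carbon gives a 32-fold higher number from compound 1 to compound 3 (1.51 log units; beyond the scatter) in this assay and marks the first large rise at this benzyl group. Replacing 3-methoxyphenyl with 2-chlorophenyl gives a 10-fold higher number from compound 2 to compound 3 (1.00 log units; beyond the scatter) and shows that these two substituted rings are far from interchangeable here. Nothing available explains this difference.

With only 3-methoxyphenyl and 2-chlorophenyl shown, the effect of the substituent cannot be separated from that of its ring position. A 3-chlorophenyl or 2-methoxyphenyl compound would help to separate them.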